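The source may hold more compounds than are shown below. What is called first, only, known or untested is meant among the compounds shown, and "the series" means these compounds.

Measured so far:
compound 1 `COc1cccc(-c2c(C)n(Cc3ccccc3F)c3nc(C(C)(C)C)c(CN(C)C)n3c2=O)c1` — 1700 nM
compound 2 `CCN(CC)CCN(C)Cc1c(C(C)(C)C)nc2n(Cc3ccccc3F)c(C)c(-c3cccc(OC)c3)c(=O)n12` — 260 nM

For the measured compounds named here, in an assay on isolated protein for binding affinity to Gonadotropin-releasing hormone receptor (Homo sapiens) (on this read-out lower numbers stand for stronger inhibition and higher numbers for weaker inhibition), compound 2 gives the lower of the two numbers, and the single measured step, a 6.5-fold lower number from compound 1 to compound 2 (0.82 log units; beyond the scatter), shows how far it is set apart from compound 1. Compound 3 `COc1cccc(-c2c(C)n(Cc3ccccc3F)c3nc(C(C)(C)C)c(CN(C)Cc4ccccc4)n3c2=O)c1` is not yet measured in this assay. It differs from compound 2 by phenyl in place of (diethylamino)methyl on a saturated chain carbon bound to an amine nitrogen. Going by the values given here, the one step that bears on this change is a 6.5-fold lower number from compound 1 to compound 2 (0.82 log units; beyond the scatter), in which the (diethylamino)methyl group entered; compound 3 gives that group up again and carries a phenyl in its place. Nothing measured shows what a phenyl at this position does, so the expectation is that part of the gain seen from compound 1 to compound 2 is lost. Compound 3 is therefore expected to give a higher number than compound 2, a step of a 3.1-fold higher number from compound 2 to compound 3 (0.49 log units; beyond the scatter), with an estimate of 800 nM and a range from 250 nM to 2500 nM.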

Compound 3, inhibition constant: 72 nM
Estimate against measurement, compound 3: 11-fold (1.05 log units) above; measured number below the stated range.
By their numbers in this assay, from the lowest: compound 3; then compound 2; then compound 1.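

In this assay, the gain at this saturated chain carbon bound to an amine nitrogen does not require the (diethylamino)methyl group: replacing it with phenyl, which has no hydrogen-bond acceptor, gives a 3.6-fold lower number from compound 2 to compound 3 (0.56 log units; beyond the scatter) and extends the gain further. Set against the hydrogen at this place, phenyl gives a 24-fold lower number from compound 1 to compound 3 (1.37 log units; beyond the scatter) and so has the large effect here, whereas the amine-bearing group produced only a modest step. No measured evidence explains why phenyl gives the lower number.

The compounds shown do not tell whether a pyridine or cyclohexyl ring would match phenyl here, or how a methoxy or fluoro group on the phenyl ring would change the number. They also leave open how a longer chain between the amine nitrogen and the phenyl ring would read in this assay.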